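Methoxy for Methyl on a Fused-Ring Core

A few compounds are considered here, and "the series" means these few. Any claim that something is new, unique, unknown or untested is made for them only; others in the source may bear on it.

Compound 1 `CC/C(=C(/c1ccc(/C=C/C(=O)O)cc1)c1ccc2[nH]ncc2n1)c1ccccc1`: 33 nM
Compound 2 `CC/C(=C(/c1ccc(/C=C/C(=O)O)cc1)c1cnc2[nH]ncc2c1)c1ccccc1`: 302 nM
Compound 3 `CC/C(=C(/c1ccc(/C=C/C(=O)O)cc1)c1ccc2[nH]ncc2c1C)c1ccccc1`: 50 nM

In a functional assay on MCF7 cells (Homo sapiens) for cytotoxicity, read by CellTiter-Glo, with a stated time of 5 days (a lower number here means a stronger inhibitor, a higher number a weaker inhibitor), compound 3 gives 50 nM, the second highest of the three numbers; its step from compound 1, a 1.5-fold higher number from compound 1 to compound 3 (0.18 log units; within the scatter), lies within the scatter, while a 6.0-fold lower number from compound 2 to compound 3 (0.78 log units; beyond the scatter) lies beyond it. Compound 4 `CC/C(=C(/c1ccc(/C=C/C(=O)O)cc1)c1ccc2[nH]ncc2c1OC)c1ccccc1` differs from compound 3 by methoxy in place of methyl on an aromatic carbon. Going by the values given here, none of the measured steps exchanges a methyl for a methoxy; the steps that bear on it, a 9.2-fold higher number from compound 1 to compound 2 (0.96 log units; beyond the scatter) and a 6.0-fold lower number from compound 2 to compound 3 (0.78 log units; beyond the scatter), swap whole fused ring systems and say little about so small a change. The expected step is therefore a 1.4-fold higher number from compound 3 to compound 4 (0.15 log units; within the scatter), nothing beyond the scatter. Compound 4 is estimated at 70 nM, within 25 nM to 200 nM.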

Compound 4, half-maximal inhibitory concentration: 55 nM
Compound 4: the middle estimate sits 1.3-fold (0.10 log units) above what was measured; the measured number falls inside the stated range.
By their numbers in this assay, from the lowest: compounds 1, 3 and 4 (each within the scatter of the next); then compound 2.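

In this assay, going by these compounds alone, the first direct exchange at this aromatic carbon is a 1.1-fold higher number from compound 3 to compound 4 (0.04 log units; within the scatter) and the two numbers cannot be told apart. Methoxy brings a hydrogen-bond acceptor that methyl lacks, yet at this place, ortho to a fused ring and ortho to a large group, either group gives the same reading within the scatter. No measurement at hand explains this result. From the compounds shown here alone, whether an ethoxy group, an amine or a chlorine atom on this carbon would also match remains open, as does the number with plain hydrogen there.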